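From 4-Methylphenyl to 5-Bromothiophen-2-yl on the Sulfonyl

The source may report more compounds than this note shows. Statements on the series, on what has been measured and on what is new or still open speak of the compounds shown alone.

Three sulfonyl variants share one core. Compound 1 `COc1ccc(-c2cc(=O)c3c(OC)cc(OC)cc3n2S(=O)(=O)c2c(F)c(F)c(F)c(F)c2F)cc1` gives 4100 nM in a functional assay on SUP-B15 cells (Homo sapiens) for antiproliferative activity, with a stated time of 72 h; on this read-out lower numbers stand for an effect already at smaller amounts and higher numbers for an effect only at larger amounts of compound. Compound 2 `COc1ccc(-c2cc(=O)c3c(OC)cc(OC)cc3n2S(=O)(=O)c2cccc(Br)c2)cc1` reaches only the limit of this assay, > 58600 nM. Compound 3 `COc1ccc(-c2cc(=O)c3c(OC)cc(OC)cc3n2S(=O)(=O)c2ccc(C)cc2)cc1` likewise stops at a limit, > 44800 nM. Hence an at least 14-fold higher number from compound 1 to compound 2 (1.15 log units; beyond the scatter) and an at least 10-fold higher number from compound 1 to compound 3 (1.03 log units; beyond the scatter), while a step that the two limits leave unreadable from compound 2 to compound 3. Compound 3 thus has no number of its own, only a limit, as does one further compound. Compound 4 `COc1ccc(-c2cc(=O)c3c(OC)cc(OC)cc3n2S(=O)(=O)c2ccc(Br)s2)cc1` differs from it by 5-bromothiophen-2-yl in place of 4-methylphenyl on a sulfonyl sulfur. Among the compounds with values here, no measured step exchanges 4-methylphenyl for a thiophene; the steps that bear on it only show that leaving pentafluorophenyl cost much. The expected step is an at least 1.1-fold lower number from compound 3 to compound 4 (0.04 log units; that floor lies within the scatter). Compound 4 is expected to give 40000 nM, within 8000 nM to 150000 nM.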

Compound 4, half-maximal effective concentration: > 48200 nM
Compound 4: a limit, no number (the forecaster's own chance of this, stated with the estimate: 60%); at least 1.2-fold (0.08 log units) between middle value and limit.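

In this assay compound 4 gives > 48200 nM as a limit of the assay, not a number. The loss on leaving pentafluorophenyl therefore extends from the two phenyl variants to a five-membered aromatic ring, with an at least 11-fold higher number from compound 1 to compound 4 (1.07 log units; beyond the scatter) for 5-bromothiophen-2-yl on the sulfonyl sulfur. Compound 2, compound 3 and compound 4 all end at limits, and the steps among them cannot be read.

Still open, going by these compounds, is whether the fluorine atoms of compound 1 are what its value depends on. A partly fluorinated phenyl, an amine or a plain alkyl chain on the sulfonyl sulfur could test this.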